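The compounds below may be only part of what the source reports. "The series", "measured", "known", "first", "only" and "open" are said of these compounds alone.

Among the measured compounds shown here, compound 3 `CCc1ccccc1-n1nncc1CN1C(=O)C2(C(C#N)=C(N)Oc3c(N)cc4nc5ccccc5nc4c32)c2ccccc21` is the only compound here with a known number: in a functional assay on HepG2 cells (Homo sapiens) for antiproliferative activity, read by MTT assay, with a stated time of 48 h (on this read-out higher numbers stand for weaker inhibition and lower numbers for stronger inhibition), compound 3 gives 17900 nM. Compound 1 `CCOc1ccc(-n2nncc2CN2C(=O)C3(C(C#N)=C(N)Oc4c3c3nc5ccccc5nc3c3ccccc43)c3ccccc32)cc1` reaches only a limit of this assay, > 50000 nM. Compound 2 `N#CC1=C(N)Oc2c(c3nc4ccccc4nc3c3ccccc23)C12C(=O)N(Cc1cnnn1-c1ccc(F)c(Cl)c1)c1ccccc12` likewise gives only a limit, > 50000 nM. For the measured compounds named here, the one step between measured compounds, a step that the two limits leave unreadable from compound 1 to compound 2, cannot be sized, as the limit of > 50000 nM in this assay, at which 2 of the 3 values shown sit, shows. Compound 4 `Cc1ccc(C)c(-n2nncc2CN2C(=O)C3(C(C#N)=C(N)Oc4c(N)cc5nc6ccccc6nc5c43)c3ccccc32)c1` differs from compound 3 by 2,5-dimethylphenyl in place of 2-ethylphenyl on an aromatic nitrogen. Going by the values given here, no measured step shows how a change of this kind moves the number, and the one change that resembles it has no readable size. The expected step of a 1.0-fold higher number from compound 3 to compound 4 (0.00 log units; within the scatter) is thus none beyond the usual scatter. Compound 4 is estimated at 18000 nM, between 7000 nM and 48000 nM.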

Compound 4, half-maximal inhibitory concentration: > 50000 nM
Compound 4 ended at the assay's limit; the forecaster's own chance of this, stated with the estimate: 25%; middle value at least 2.7-fold (0.44 log units) from the limit.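

Among the compounds shown here, this is the first readable step at this position, on the aromatic nitrogen of a five-membered aromatic ring: in this assay, 2,5-dimethylphenyl in place of 2-ethylphenyl gives an at least 2.7-fold higher number from compound 3 to compound 4 (0.44 log units; beyond the scatter). The two groups hold the same atoms, joined differently, so rearranging those atoms alone is enough to move the number. The size of the step is only a minimum, as compound 4 reaches a limit of the assay: the limit of > 50000 nM in this assay, at which 3 of the 4 values shown sit.

The compounds shown leave open how a phenyl ring carrying an amine or a carboxylic acid would read here. They also leave open whether a longer chain in place of the ethyl would move the number in either direction.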